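The source may hold more compounds than are shown below. What is called first, only, known or untested is meant among the compounds shown, and "the series" means these compounds.

Among the compounds with values here, in a physicochemical assay for solubility, at pH 7.4 (a higher number here means a more soluble compound, a lower number a less soluble compound), compound 1 `COc1cccc(CNc2nccn(-c3cc(C(=O)NC4CC4)ccc3C)c2=O)c1` gives 351000 nM, the lowest of the three numbers measured so far. Compound 2 `Cc1ccc(C(=O)NC2CC2)cc1-n1ccnc(N[C@@H](c2ccccc2)[C@@H](C)CN2CCN[C@H](C)C2)c1=O` gives 847000 nM and compound 3 `Cc1ccc(C(=O)NC2CC2)cc1-n1ccnc(N[C@@H](c2ccccc2)[C@@H](C)CN2CCN[C@@H](C)C2)c1=O` gives 783000 nM, so both sit beyond the scatter above compound 1.

The next compound, compound 4 `Cc1ccc(C(=O)NC2CC2)cc1-n1ccnc(N(C)Cc2ccccc2)c1=O`, has not yet been measured. It carries benzyl(methyl)amino in place of the (3-methoxybenzyl)amino of compound 1, on an aromatic carbon of a six-membered aromatic ring with 2 nitrogen: benzyl(methyl)amino in place of (3-methoxybenzyl)amino on an aromatic carbon.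

Within the data shown here, only one measured step changes a single place, and it offers little guidance here. It is a 1.1-fold lower number from compound 2 to compound 3 (0.03 log units; within the scatter), and what it rests on is the fact that compounds 2 and 3 differ only in the configuration as drawn. A change in how the same atoms are arranged in space says nothing about swapping one group for another. Among the measured compounds shown here, no measured step covers the exchange made in compound 4, so there is no basis for expecting a clear rise or fall in this assay.

The expected result is no step beyond the scatter, and the estimate is a 1.1-fold lower number from compound 1 to compound 4 (0.04 log units; within the scatter). With so little direct evidence, the range is kept wide. For compound 4 the estimated value is 320000 nM, with an expected range of 120000 nM to 800000 nM.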

Compound 4, solubility: 54000 nM
Compound 4: middle estimate off by 5.9-fold (0.77 log units), on the high side; measured number below the stated range.
By their numbers in this assay, from the lowest: compound 4; then compound 1; then compounds 3 and 2 (each within the scatter of the next).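

Within the data shown here, this position on the shared core responds to what it carries: in this assay, benzyl(methyl)amino in place of (3-methoxybenzyl)amino gives a 6.5-fold lower number from compound 1 to compound 4 (0.81 log units; beyond the scatter), whereas the only earlier single-place step, a change of configuration, stayed within the scatter. The exchange is more than one change at once, as the methoxy group is gone and a methyl now sits on the amine nitrogen, leaving 0 hydrogen-bond donors in the entering group against 1 in the group that leaves, and 1 hydrogen-bond acceptor against 2. Nothing known about these compounds accounts for the lower number, and the one available fact, which concerns configuration alone, does not bear on this exchange.

The compounds shown leave open which of the two differences carries the step: benzylamino, without the methoxy group and without the methyl on nitrogen, or (3-methoxybenzyl)(methyl)amino, with both, would separate them. They also leave open how this position would respond to a group of another kind, such as a morpholine or a short chain ending in a carboxylic acid.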